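A few compounds are considered here, and "the series" means these few. Any claim that something is new, unique, unknown or untested is made for them only; others in the source may bear on it.

Compounds measured in an assay on Sf21 cells for inhibition of high affinity nerve growth factor receptor (Homo sapiens), read by HTRF, with a stated time of 30 min, in the presence of a further agent that is not named here; on this read-out lower numbers stand for stronger inhibition and higher numbers for weaker inhibition:
compound 1 `CC1(C)c2[nH]nc(NC(=O)c3ccccc3)c2CN1Cc1cccc(I)c1` — 1360 nM
compound 2 `CC1(C)c2[nH]nc(NC(=O)c3ccccc3)c2CN1Cc1cc(F)cc(F)c1` — 190 nM
compound 3 `CC1(C)c2[nH]nc(NC(=O)c3ccccc3)c2CN1Cc1cc(F)c(F)c(F)c1` — 6960 nM

Compound 2 gives the lowest number of the three in this assay. The step of a 7.2-fold lower number from compound 1 to compound 2 (0.85 log units; beyond the scatter) and the step of a 37-fold higher number from compound 2 to compound 3 (1.56 log units; beyond the scatter) both lie beyond the scatter, so compound 2 stands clear of both neighbours; the step of a 5.1-fold higher number from compound 1 to compound 3 (0.71 log units; beyond the scatter) completes the picture. All three measured steps concern the group on the saturated chain carbon bound to the amine nitrogen in the ring.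

Compound 4 `CN1CCN(c2ccc(C(=O)Nc3n[nH]c4c3CN(Cc3cc(F)cc(F)c3)C4(C)C)cc2)CC1` keeps the 3,5-difluorophenyl of compound 2 unchanged and differs only in 4-methylpiperazin-1-yl in place of hydrogen on an aromatic carbon. For the measured compounds named here, no measured step touches this aromatic ring, so none of the three steps bears on the change directly; the shared core and the difluorophenyl group are held constant. With nothing in the measured set pointing either way, the expectation is a step of a 1.3-fold lower number from compound 2 to compound 4 (0.10 log units; within the scatter) not beyond the scatter, and compound 4 is estimated at 150 nM in this assay, within a range from 40 nM to 600 nM.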

Compound 4, half-maximal inhibitory concentration: 17 nM
For compound 4 the middle estimate is 8.8-fold (0.95 log units) above the measured one; measured number outside the range, below it.
By their numbers in this assay, from the lowest: compound 4; then compound 2; then compound 1; then compound 3.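

In this assay, the change gives an 11-fold lower number from compound 2 to compound 4 (1.05 log units; beyond the scatter), with the 3,5-difluorophenyl group and the shared core held constant. For the compounds shown here, this is the first sign that the six-membered aromatic ring of carbon only, which no earlier step touched, also moves the number, and that a group as large as 4-methylpiperazin-1-yl is accepted para to a large group, with the number falling rather than rising. Nothing available explains this shift.

A single substituent cannot show whether the step belongs to the ring itself or to its nitrogens; morpholine, piperidine or a dimethylamino group at this place would separate these readings. Also open, going by these compounds, is whether 4-methylpiperazin-1-yl would give a similar step alongside the 3-iodophenyl of compound 1 or the 3,4,5-trifluorophenyl of compound 3.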